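Moving the Hydroxyl on a Sulfonamide Aniline

The source may report more compounds than this note shows. Statements on the series, on what has been measured and on what is new or still open speak of the compounds shown alone.

Measured compounds:
compound 1, `CC(C)(C)c1ccc(S(=O)(=O)Nc2ccc(O)cc2)cc1`: 5000 nM
compound 2, `O=S(=O)(Nc1ccc(O)cc1)c1ccc(-c2ccccc2)cc1`: 2500 nM; 5000 nM (2 entries)

Both compounds were tested in an assay on HepG2 cells for inhibition of cytochrome b-c1 complex subunit 7 (Homo sapiens), read by Western blot, with a stated time of 4 h; a lower number here means a stronger inhibitor, a higher number a weaker inhibitor. Among the compounds with values here, compound 1 gives 5000 nM and is the only compound here with a single plain number. Compound 2 has repeated entries, (the several entries of compound 2 in this assay, 2500 nM; 5000 nM (2 entries)), and those entries lie within the usual scatter of one another and of the value of compound 1, so no difference between the two can be read from this set.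

Compound 3, `CC(C)(C)c1ccc(S(=O)(=O)Nc2ccccc2O)cc1`, has not yet been measured in this assay. It is built from the same atoms as compound 1, joined differently: 2-hydroxyphenyl in place of 4-hydroxyphenyl on a sulfonamide nitrogen. Within the data shown here, no measured pair in this set shows such a change, so there is no measured step to lean on.

The expected step from compound 1 to compound 3 is a 1.4-fold higher number from compound 1 to compound 3 (0.15 log units; within the scatter), a small shift toward weaker inhibition that may well fall inside the scatter. Compound 3 is therefore estimated at 7000 nM, within a range of 2000 nM to 25000 nM.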

Compound 3, half-maximal inhibitory concentration: 8000 nM
Beside the measured number, compound 3's estimate is 1.1-fold (0.06 log units) below it; measured number inside the range.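

In this assay, 2-hydroxyphenyl in place of 4-hydroxyphenyl on a sulfonamide nitrogen gives a 1.6-fold higher number from compound 1 to compound 3 (0.20 log units; within the scatter), so this change cannot be told apart from no change at all. Compound 1 and compound 2 both carry 4-hydroxyphenyl at this place, so they could say nothing about where the hydroxyl may sit; compound 3 shows that moving it, with the same atoms joined differently, leaves the result within the usual scatter of the assay. The step is also no larger than the spread that repeated readings of a single compound show here: the several entries of compound 2 in this assay, 2500 nM; 5000 nM (2 entries)

What the compounds shown leave open is whether the hydroxyl itself matters, since all of them carry one on this ring, and a plain phenyl, or an amine or methoxy group in the hydroxyl's place, would speak to that. Also open, going by these compounds, is whether 2-hydroxyphenyl in place of 4-hydroxyphenyl would give a similarly small step on the core of compound 2.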